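Substituent change on the fused ring: toward compound 3

This account rests on a few compounds, and the source may have more. Where it says the series, first, only, none or still open, it means among the compounds named here.

Measured so far:
compound 1, `O=C1C[C@H](O)C[C@@H](/C=C/c2c(C3CC3)nc3ccccc3c2Sc2ccc(F)cc2)O1`, 62400 nM
compound 2, `O=C1C[C@H](O)C[C@@H](/C=C/c2c(C3CC3)nc3ccc(F)cc3c2Sc2ccc(F)cc2)O1`, 6930 nM

In an assay on isolated protein for inhibition of 3-hydroxy-3-methylglutaryl-coenzyme A reductase (Homo sapiens), read by spectrophotometry (a lower number here means a stronger inhibitor, a higher number a weaker inhibitor), compound 1 gives 62400 nM and compound 2 gives 6930 nM. Among the compounds with values here, compound 2 holds the lower of the two numbers so far; its only neighbour is compound 1, and the one measured step, a 9.0-fold lower number from compound 1 to compound 2 (0.95 log units; beyond the scatter), lies beyond the scatter.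

Compound 3, `COc1ccc2nc(C3CC3)c(/C=C/[C@@H]3C[C@@H](O)CC(=O)O3)c(Sc3ccc(F)cc3)c2c1`, is still to be measured. Its change from compound 2 is methoxy in place of fluoro on an aromatic carbon. Within the data shown here, no measured step covers a methoxy at this place. Among the measured compounds shown here, the only step that touches the same aromatic carbon, a 9.0-fold lower number from compound 1 to compound 2 (0.95 log units; beyond the scatter), shows that what sits there can move the number by a modest amount, but it compares fluoro with hydrogen, not methoxy with fluoro. The direction for compound 3 therefore cannot be read from the data; the number is expected to stay in the neighbourhood of compound 2, with a wide range spanning both directions.

Compound 3 is estimated at 9000 nM, with a range from 2500 nM to 35000 nM. The expected step is a 1.3-fold higher number from compound 2 to compound 3 (0.11 log units; within the scatter), which is within the scatter.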

Compound 3, half-maximal inhibitory concentration: 25700 nM
Compound 3: the middle estimate sits 2.9-fold (0.46 log units) below what was measured; low and high end bracket the measured number.
By their numbers in this assay, from the lowest: compound 2; then compound 3; then compound 1.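

In this assay, this aromatic carbon now has three substituents to compare, and they are not interchangeable: a 3.7-fold higher number from compound 2 to compound 3 (0.57 log units; beyond the scatter), so methoxy does not match fluoro here. Methoxy still gives a lower number than hydrogen, with a 2.4-fold lower number from compound 1 to compound 3 (0.39 log units; beyond the scatter), but this step is smaller than a 9.0-fold lower number from compound 1 to compound 2 (0.95 log units; beyond the scatter), which places methoxy between hydrogen and fluoro across these compounds. No measurement available here bears on the reason for this order.

From the compounds shown here alone, it remains open whether other groups at this aromatic carbon, such as chloro, hydroxy, ethoxy or an amine, would fall within the span set by fluoro and hydrogen or outside it, so three compounds give an order but no trend. Also open, going by these compounds, is whether the same order of fluoro, methoxy and hydrogen would hold if the shared core carried a different group elsewhere.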